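A few compounds are considered here, and "the series" means these few. Any claim that something is new, unique, unknown or untested is made for them only; others in the source may bear on it.

Series notes, working state. Compound 1 `COc1ccc(-c2sc(N)c(C(=O)c3ccc(Cl)cc3)c2C)cc1` is the reference point. In an assay on CHO cells for displacement of a labelled ligand from adenosine receptor A1 (Homo sapiens), read by scintillation counting, tested at 10 uM (a higher number here means more inhibition at the concentration tested (going by the name of the read-out), a lower number less inhibition), compound 1 gives 1%. Compound 2 `Nc1sc(-c2ccccc2)c(-c2ccccc2)c1C(=O)c1ccc(Cl)cc1` gives 1% in this assay, and compound 3 `CC(C)(C)Cc1c(-c2ccccc2)sc(N)c1C(=O)c1ccccc1Cl` gives 1% in the same assay. Compound 1 stands level with compounds 2 and 3 at the digits reported: the nearest of the two is compound 2 and the furthest is compound 3, and in neither case does the gap reach beyond the usual scatter. Going by the values given here, no step between two measured compounds that differ in a single place is available, so the three values supply no measured direction for any one change on the shared core.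

Compound 4 `COc1ccc(-c2sc(N)c(C(=O)c3ccc(Cl)cc3)c2CC(C)(C)C)cc1` is the next compound to be measured. It differs from compound 1 in one place: tert-butyl in place of hydrogen on a saturated chain carbon bound to an aromatic carbon. The three measured compounds carry differing substitution on the shared core, yet all of them sit at the same low level of the read-out, with no spread beyond the scatter among them. The expectation for the step from compound 1 to compound 4 in this assay is therefore none beyond the scatter, no change at the digits printed from compound 1 to compound 4 (within the scatter). Compound 4 is estimated to give 1%, with an expected range of 0% to 8%.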

Compound 4, a percentage reported as inhibition, at one concentration (the size of the read-out at that concentration, not a potency): 1%
The estimate for compound 4 equals the measured number at the digits printed; low and high end bracket the measured number.
By their numbers in this assay, from the lowest: compounds 1, 2, 3 and 4 (each within the scatter of the next).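

In this assay, going by these compounds alone, the first step on the shared core that differs in one place reads no change at the digits printed from compound 1 to compound 4 (within the scatter), with tert-butyl in place of hydrogen on a saturated chain carbon bound to an aromatic carbon. This position therefore takes the methyl to neopentyl difference, 4 heavy atoms entering with no ring and no hydrogen-bond donors or acceptors, without any inhibition appearing in this assay, although with compound 1 at 1% a loss could hardly be read from this starting level. No measured evidence bears on this result.

The compounds shown leave open whether an amine or a carboxylic acid carried on this chain carbon would lift the read-out from this low level, as all the groups compared at this place so far are plain carbon groups. Within the data shown here, also open is whether the neopentyl group would read the same with a different aryl group on the shared core, as compounds 2 and 3 are linked to compound 1 by no single-place step.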